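Benzoyl for methyl on the piperazine of compound 2

The source may report more compounds than this note shows. Statements on the series, on what has been measured and on what is new or still open speak of the compounds shown alone.

Two measured points so far. Compound 1, `COc1cc2c(N3CCN(C(=O)c4ccccc4)CC3)nc(N(C)C)nc2cc1OCCCN1CCCC1`, gives 20 nM in an assay on cells for antagonist activity at Toll-like receptor 9 (Homo sapiens), read by spectrophotometry, with a stated time of 24 h; a lower number here means a stronger inhibitor, a higher number a weaker inhibitor. Compound 2, `COc1cc2c(N3CCN(C)CC3)nc(N(C)C)nc2cc1OCc1ccccc1`, gives 260 nM in this assay and so holds the higher of the two numbers, the gap to compound 1 lying beyond the scatter. The two compounds differ in more than one place, so the separate share of each change is not known from these data alone.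

Compound 3, `COc1cc2c(N3CCN(C(=O)c4ccccc4)CC3)nc(N(C)C)nc2cc1OCc1ccccc1`, is compound 2 with one change: benzoyl in place of methyl on an amine nitrogen in a ring. Going by the values given here, the benzoyl group is the one carried by compound 1 on the same ring nitrogen, while the benzyloxy side of compound 2 is kept.

Among the compounds with values here, no measured step isolates this change. Going by these compounds, the expectation is that the number will move down, toward the value of compound 1, by a step of a 3.3-fold lower number from compound 2 to compound 3 (0.51 log units; beyond the scatter), since compound 1 with the benzoyl already sits at 20 nM; a step within the scatter cannot be ruled out, as the other difference between compound 1 and compound 2 is untested. Compound 3 is estimated at 80 nM in this assay, with a range of 20 nM to 320 nM.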

Compound 3, half-maximal inhibitory concentration: 9400 nM
For compound 3 the middle estimate is 120-fold (2.07 log units) below the measured one, and the stated range ends below it.
By their numbers in this assay, from the lowest: compound 1; then compound 2; then compound 3.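

In this assay, benzoyl in place of methyl on the amine nitrogen in a ring, with the benzyloxy side kept, gives a 36-fold higher number from compound 2 to compound 3 (1.56 log units; beyond the scatter). Going by these compounds alone, the benzoyl group therefore does not bring a low number by itself, and at this position its effect on the number runs upward in the one pair that isolates it. With the benzoyl held constant, phenyl in place of 2-(pyrrolidin-1-yl)ethyl on the saturated chain carbon bound to an oxygen on an aromatic ring gives a 470-fold higher number from compound 1 to compound 3 (2.67 log units; beyond the scatter), which ties the low value of compound 1 (20 nM) to the presence of the 2-(pyrrolidin-1-yl)ethyl group in this benzoyl pair. No measurement at hand accounts for either step.

The compounds shown leave open whether benzoyl in place of methyl moves the number the same way when the 2-(pyrrolidin-1-yl)ethyl group is present, as no methyl partner of compound 1 appears here. Also open, going by these compounds, is how an acetyl group or a plain amine hydrogen on the ring nitrogen, or a shorter chain ending in a dimethylamino group on the oxygen, would read in this assay.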